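The source may hold more compounds than are shown below. What is called first, only, known or untested is meant among the compounds shown, and "the series" means these compounds.

Compound 1 `O=C(NCc1ccc(F)cc1)c1cc(S(=O)(=O)N2CCCCC2)cc(O)c1O` gives 13000 nM in an ADME assay on NCI-H630 cells (Homo sapiens) for cytotoxicity, read by MTT assay, with a stated time of 72 h; a higher number here means that more compound is tolerated, a lower number that less compound is tolerated.
Compound 2 `O=C(NCc1ccco1)c1cc(S(=O)(=O)N2CCCCC2)cc(O)c1O` gives 33000 nM in this assay.
Compound 3 `CN(C)Cc1ccc(C(=O)NCc2ccc(F)cc2)c(O)c1O` gives > 10000 nM in this assay; this is a limit of the assay, not a number.

Compound 1 and compound 2 share one core and differ by furan-2-yl in place of 4-fluorophenyl on a saturated chain carbon bound to an amide-type nitrogen. That change produced a 2.5-fold higher number from compound 1 to compound 2 (0.40 log units; beyond the scatter). Compound 3 has a different core, and how the two cores differ is not broken down here. Compound 4 `CN(C)Cc1ccc(C(=O)NCc2ccco2)c(O)c1O` has not yet been measured; it differs from compound 3 by furan-2-yl in place of 4-fluorophenyl on a saturated chain carbon bound to an amide-type nitrogen, the same change seen between compound 1 and compound 2. For compound 3 only a limit exists in this assay: the limit of > 10000 nM in this assay, at which 1 of the 3 values shown sits. Because compound 3 already sits at the limit of > 10000 nM in this assay, at which 1 of the 3 values shown sits, and the same change gave a 2.5-fold higher number from compound 1 to compound 2 (0.40 log units; beyond the scatter), compound 4 is expected to tolerate a comparable or larger amount, and its step is estimated as a step that the limit leaves unreadable from compound 3 to compound 4. Compound 4 is thus expected around 25000 nM, in the range 10000 nM to 80000 nM, most likely again only as a limit.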

Compound 4, half-maximal cytotoxic concentration: 7000 nM
The estimate for compound 4 lay 3.6-fold (0.55 log units) above the measured number; measured number outside the range, below it.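

Moved to a second core, furan-2-yl in place of 4-fluorophenyl gave an at least 1.4-fold lower number from compound 3 to compound 4 (0.15 log units; that floor lies within the scatter). Set beside the first core, the change did not carry over in this assay, and the two steps point in opposite directions: the same change on two cores in this assay, a 2.5-fold higher number (0.40 log units; beyond the scatter) from compound 1 to compound 2 and an at least 1.4-fold lower number (0.15 log units; that floor lies within the scatter) from compound 3 to compound 4, at least 3.6-fold (0.55 log units) apart, beyond the scatter of two such steps

From the compounds shown here alone, this shows that, for these two pairs, the outcome of the change depends on the core, but two pairs cannot show which difference between the cores matters, and the full size of the new step stays unknown, the value of compound 3 being only a limit of the assay.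

The compounds shown leave open how thiophen-2-yl or plain phenyl would behave on a saturated chain carbon bound to an amide-type nitrogen on each core in this assay.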